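Anilide variation on the nitrocatechol acrylonitrile series

The compounds below may be only part of what the source reports. "The series", "measured", "known", "first", "only" and "open" are said of these compounds alone.

Two compounds of the series have numbers in a functional assay on Bel-7402 cells (Homo sapiens) for antiproliferative activity, read by MTT assay; on this read-out lower numbers stand for stronger inhibition and higher numbers for weaker inhibition. Compound 1 `N#C/C(=C\c1cc(O)c(O)c([N+](=O)[O-])c1)C(=O)N(c1ccccc1)c1ccccc1` gives 56.2 ug/mL. Compound 2 `Cc1cccc(NC(=O)/C(C#N)=C/c2cc(O)c(O)c([N+](=O)[O-])c2)c1` gives 13.1 ug/mL, the lowest of the two numbers; the gap to compound 1 lies beyond the usual scatter of repeated measurements. Among the measured compounds shown here, no step between two compounds differing in a single place has been recorded, so no measured single change of this kind is available for comparison.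

Compound 3 `COc1ccc(NC(=O)/C(C#N)=C/c2cc(O)c(O)c([N+](=O)[O-])c2)cc1` remains to be measured in this assay. It differs from compound 2 in one place: 4-methoxyphenyl in place of 3-methylphenyl on an amide-type nitrogen. The only reference for the size of such a change is the distance between compound 1 and compound 2, which concerns a different alteration of the amide substituent and so gives no direct guide here.

The expectation for compound 3 is a number close to that of compound 2, with the step of a 1.1-fold higher number from compound 2 to compound 3 (0.06 log units; within the scatter) expected to stay within the scatter, in either direction. Compound 3 is estimated at 15 ug/mL, with a range from 6 ug/mL to 40 ug/mL.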

Compound 3, half-maximal inhibitory concentration: > 100 ug/mL
Compound 3 ended at the assay's limit; the forecaster's own chance of this, stated with the estimate: 5%; middle value at least 6.6-fold (0.82 log units) from the limit.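

Compound 3 gives > 100 ug/mL in this assay, and this value is a limit of the assay, not a number. On the amide-type nitrogen whose other neighbour is the carbonyl carbon, the series now has its first readable single change, an at least 7.6-fold higher number from compound 2 to compound 3 (0.88 log units; beyond the scatter), so the number at this position depends strongly on the aryl group even though 3-methylphenyl and 4-methoxyphenyl each carry one six-membered aromatic ring of carbon only. The size of this step is a lower bound, and how far compound 3 really lies from compound 2 stays unknown: the limit of > 100 ug/mL in this assay, at which 1 of the 3 values shown sits.

The change alters both the substituent and its place on the ring, and the compounds shown cannot separate these two parts, so it remains unclear which of them carries the loss. Also open, on these data alone, is how an unsubstituted phenyl, or a ring bearing a hydroxyl or a chlorine, would compare with compound 2 at 13.1 ug/mL.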